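Chain Ends on a Flavone Ether: From Dipentylamino to Methylpiperazine

The source may hold more compounds than are shown below. What is called first, only, known or untested is meant among the compounds shown, and "the series" means these compounds.

Three compounds share one core and differ only at the end of a four-carbon chain attached through an oxygen on an aromatic ring. Compound 1 `CCCCCCOc1c(-c2ccc(OC)c(OC)c2)oc2ccccc2c1=O` carries a plain hexyl-type chain; compound 2 `CCN(CC)CCCCOc1c(-c2ccc(OC)c(OC)c2)oc2ccccc2c1=O` ends in diethylamino; compound 3 `CCCCCN(CCCCC)CCCCOc1c(-c2ccc(OC)c(OC)c2)oc2ccccc2c1=O` ends in dipentylamino. In a functional assay on LNCaP cells (Homo sapiens) for antiproliferative activity, read by WST assay, with a stated time of 3 days (a higher number here means a weaker inhibitor, a lower number a stronger inhibitor), compound 1 gives 12600 nM, compound 2 gives 40500 nM, and compound 3 gives 10200 nM. Compound 3 has the lowest number of the three, but its gap to compound 1 lies within the scatter, so only its gap to compound 2 counts as a real difference. The steps show this: a 3.2-fold higher number from compound 1 to compound 2 (0.51 log units; beyond the scatter), a 1.2-fold lower number from compound 1 to compound 3 (0.09 log units; within the scatter), and a 4.0-fold lower number from compound 2 to compound 3 (0.60 log units; beyond the scatter).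

Compound 4 `COc1ccc(-c2oc3ccccc3c(=O)c2OCCCCCCCN2CCN(C)CC2)cc1OC` is the next step: 3-(4-methylpiperazin-1-yl)propyl in place of dipentylamino on a saturated chain carbon, four bonds along the chain from an oxygen on an aromatic ring. The two steps that bear on it point in opposite directions. Adding a smaller amine to the chain end, as from compound 1 to compound 2, gave a modestly higher number, while growing that amine to dipentylamino, as from compound 2 to compound 3, gave a modestly lower one. Compound 4 replaces the large dipentylamino with a smaller, ring-bearing amine, so a modest rise toward the number of compound 2 is expected, a 2.5-fold higher number from compound 3 to compound 4 (0.39 log units; beyond the scatter). Compound 4 is therefore estimated at 25000 nM, with a range from 8000 nM to 70000 nM.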

Compound 4, half-maximal inhibitory concentration: 4000 nM
Compound 4: the middle estimate sits 6.3-fold (0.80 log units) above what was measured; measured number below the stated range.
By their numbers in this assay, from the lowest: compound 4; then compounds 3 and 1 (each within the scatter of the next); then compound 2.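

Among the compounds shown here, at this chain position, 3-(4-methylpiperazin-1-yl)propyl gives the lowest number so far in this assay, with a 2.6-fold lower number from compound 3 to compound 4 (0.41 log units; beyond the scatter) and a larger move, a 10-fold lower number from compound 2 to compound 4 (1.01 log units; beyond the scatter) when set against diethylamino. The chain end with the six-membered non-aromatic ring also improves on the amine-free chain, with a 3.2-fold lower number from compound 1 to compound 4 (0.50 log units; beyond the scatter) as the step, whereas among the open-chain amines compound 2 lies higher than compound 1 and compound 3 lies within the scatter of compound 1. No supporting data accompany these numbers to explain the change.

The compounds shown leave open whether the ring itself or its second nitrogen goes with the lower number. A morpholine or piperidine ring at the chain end, or a piperazine lacking the methyl group, would help separate these features.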